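Pyridine Replaces Chlorothiophene on a Fatty Acid Receptor Agonist

The source may hold more compounds than are shown below. What is called first, only, known or untested is meant among the compounds shown, and "the series" means these compounds.

Three measured compounds share one core: an acid-bearing chain on an aromatic ring whose nitrogen carries a single saturated carbon linking to a second aromatic group. In a functional assay for agonist activity at Free fatty acid receptor 1 (Homo sapiens) (a higher number here means that more compound is needed for the effect, a lower number that less compound is needed), compound 1 `O=C(O)CCCc1ccc(NCc2ccc(-c3ccccc3)cc2)cc1` gives 1580 nM. In this assay compound 2 `O=C(O)CCc1ccc(NCc2cccc(Br)c2)cc1` gives 794 nM. In this assay compound 3 `O=C(O)CCc1ccc(NCc2ccc(Cl)s2)cc1` gives 2000 nM, the highest of the three numbers; the values of compound 3 and compound 1 lie within the usual scatter of each other, whereas compound 2 sits clearly apart with a lower number.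

Compound 4 `O=C(O)CCc1ccc(NCc2cccnc2)cc1` has not yet been measured. It differs from compound 3 in one place: pyridin-3-yl in place of 5-chlorothiophen-2-yl on a saturated chain carbon bound to a nitrogen on an aromatic ring. For the measured compounds named here, no step among the measured compounds involves this kind of exchange, so the expectation rests only on where compound 3 stands and on the spread the three numbers already show. The expected step is a 2.0-fold higher number from compound 3 to compound 4 (0.30 log units; within the scatter), a modest move toward a higher number that could still fall inside the scatter. For compound 4 the value in this assay is estimated at 4000 nM, with a plausible range from 1300 nM to 15000 nM.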

Compound 4, half-maximal effective concentration: < 31700 nM
Compound 4: only a limit was reported (the forecaster's own chance of this, stated with the estimate: 20%); the middle value is on the limit's open side.
By their numbers in this assay, from the lowest: compounds 2, 1 and 3 (each within the scatter of the next, the first and the last beyond it).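

In this assay compound 4 gives < 31700 nM as a limit and not a number. For the compounds shown here, the change from compound 3 to compound 4 therefore gives no step that can be read: the limit of < 31700 nM in this assay, at which 1 of the 4 values shown sits. The compounds shown leave open whether pyridin-3-yl in place of 5-chlorothiophen-2-yl moves the number up or down, and how far.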